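The source may hold more compounds than are shown below. What is called first, only, known or untested is meant among the compounds shown, and "the series" means these compounds.

Three compounds that share one core and differ in a single group have been tested so far in a functional assay on B16-F0 cells (Mus musculus) for inhibition, read by CCK-8 assay, with a stated time of 48 h (a higher number here means a weaker inhibitor, a lower number a stronger inhibitor), and are compared here by their half-maximal inhibitory concentration. With a vinyl group, compound 1 `C=Cc1ccc(-c2cc3nccc(-c4cc(OC)c(OC)c(OC)c4)n3n2)cc1` gives 788 nM in this comparison. With an acetyl group, compound 2 `COc1cc(-c2ccnc3cc(-c4ccc(C(C)=O)cc4)nn23)cc(OC)c1OC` gives 3930 nM in the same read-out. Compound 3 `CCOC(=O)c1ccc(-c2cc3nccc(-c4cc(OC)c(OC)c(OC)c4)n3n2)cc1`, with ethoxycarbonyl, is reported only as the limit > 10000 nM and not as an exact number.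

Replacing vinyl gave a 5.0-fold higher number from compound 1 to compound 2 (0.70 log units; beyond the scatter) with acetyl, a modest step, and an at least 12-fold higher number from compound 1 to compound 3 (1.10 log units; beyond the scatter) with ethoxycarbonyl, a large one. Going from acetyl to ethoxycarbonyl gave an at least 2.5-fold higher number from compound 2 to compound 3 (0.40 log units; beyond the scatter) on top of that.

Compound 4 `COc1cc(-c2ccnc3cc(-c4ccc(C(C)(C)C)cc4)nn23)cc(OC)c1OC` carries tert-butyl in place of ethoxycarbonyl on an aromatic carbon, and the change is tert-butyl in place of ethoxycarbonyl on an aromatic carbon in full. Tert-butyl has no carbonyl, and neither has the vinyl of compound 1, which stands apart from the two carbonyl compounds through an at least 12-fold higher number from compound 1 to compound 3 (1.10 log units; beyond the scatter) and the smaller step to compound 2. Going by the values given here, no tested compound carries tert-butyl, so the size stays uncertain. In this assay a move to a lower number, of at least modest size, is expected, and the estimated step is an at least 5.0-fold lower number from compound 3 to compound 4 (0.69 log units; beyond the scatter) for this change. Compound 4 is estimated at 2000 nM within an expected range from 500 nM to 8000 nM overall.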

Compound 4, half-maximal inhibitory concentration: > 10000 nM
Compound 4: only a limit was reported; the forecaster's own chance of this, stated with the estimate: 15%; middle value at least 5.0-fold (0.69 log units) away from the limit.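

In this assay compound 4 is reported only as a limit, > 10000 nM, and not as an exact number. The step between compound 3 and compound 4 cannot be read, because both rest on the same limit: the limit of > 10000 nM in this assay, at which 2 of the 4 values shown sit. What compound 4 adds is that a carbonyl is not needed for a poor result at this place on the aromatic ring: tert-butyl has no carbonyl and no hydrogen-bond acceptors, yet it brings an at least 12-fold higher number from compound 1 to compound 4 (1.10 log units; beyond the scatter) and also an at least 2.5-fold higher number from compound 2 to compound 4 (0.40 log units; beyond the scatter), so the absence of a carbonyl does not by itself keep the number as low as the vinyl of compound 1 does.

As far as these compounds go, how far compound 3 and compound 4 lie past the limit remains unknown, so neither can be ranked against the other. From the compounds shown here alone, it also remains open whether an ethyl group, an amine or a carboxylic acid at this same place would give a number close to that of compound 1, or whether vinyl stands alone among such replacements.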